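From nitro to chloro: what compound 4 may show

The source may report more compounds than this note shows. Statements on the series, on what has been measured and on what is new or still open speak of the compounds shown alone.

Values so far in a functional assay on RS4-11 cells (Homo sapiens) for inhibition, read by CCK-8 assay, with a stated time of 48 h, tested at 20 uM; a higher number here means more inhibition of growth at the concentration tested, a lower number less inhibition of growth
compound 1 `COc1ccc(Cc2nnc(NC(=O)/C(C#N)=C/c3ccccc3OS(=O)(=O)c3ccc(Cl)cc3)s2)cc1` gives 79%
compound 2 `COc1ccc(S(=O)(=O)Oc2ccccc2/C=C(\C#N)C(=O)Nc2nnc(Cc3cccc4ccccc34)s2)cc1` gives 78%
compound 3 `N#C/C(=C\c1ccccc1OS(=O)(=O)c1ccc([N+](=O)[O-])cc1)C(=O)Nc1nnc(Cc2cccc3ccccc23)s1` gives 58%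

Compound 3 (58%) is the lowest of the three, and both other numbers lie above it by more than the usual scatter. The unmeasured compound 4 `N#C/C(=C\c1ccccc1OS(=O)(=O)c1ccc(Cl)cc1)C(=O)Nc1nnc(Cc2cccc3ccccc23)s1` differs from it in one place: chloro in place of nitro on an aromatic carbon. This is chloro in place of nitro on an aromatic carbon, so 4-nitrophenyl becomes 4-chlorophenyl.

Among the measured compounds shown here, one measured step bears on this directly. Putting nitro in place of methoxy at that same place gave a number 20 percentage points lower from compound 2 to compound 3 (beyond the scatter), a modest step beyond the scatter. Compound 1 also carries the 4-chlorophenyl group and gives 79%, but it differs elsewhere, so it is only a loose guide. For the measured compounds named here, no measurement yet shows chloro on the exact background of compound 3, so a partial recovery seems the safest expectation. The estimate is therefore a number 14 percentage points higher from compound 3 to compound 4 (beyond the scatter), a modest rise in this assay. For compound 4 the expected value is 72% (estimated range 58% to 86%).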

Compound 4, percent growth inhibition at one concentration: 68%
The estimate for compound 4 lay 4 percentage points above the measured number, within the range that was stated.
By their numbers in this assay, from the lowest: compounds 3, 4, 2 and 1 (each within the scatter of the next, the first and the last beyond it).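

With naphthalen-1-yl held fixed, chloro in place of nitro gives a number 10 percentage points higher from compound 3 to compound 4 (within the scatter) in this assay, and chloro in place of methoxy gives a number 10 percentage points lower from compound 2 to compound 4 (within the scatter) on the same background. Chloro therefore cannot be told apart from either group at this place, although methoxy and nitro do separate from each other beyond the scatter. The other end of the molecule also counts: with 4-chlorophenyl held fixed, naphthalen-1-yl in place of 4-methoxyphenyl gives a number 11 percentage points lower from compound 1 to compound 4 (beyond the scatter), and no measurement here explains any of these differences.

Still open, on these data alone, is how an amine or a carboxylic acid would behave at this aromatic carbon. Also open, as far as these compounds go, is whether the gap between naphthalen-1-yl and 4-methoxyphenyl would persist with methoxy or nitro on the sulfonyl ring.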